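One Ring Swap in a Seizure Model

The source may hold more compounds than are shown below. What is called first, only, known or untested is meant among the compounds shown, and "the series" means these compounds.

Three compounds sharing one core were tested in a functional assay on the whole organism (strain Swiss) with Mus musculus as the target, in the maximal electroshock model, with a stated time of 2 h, at a dose of 100 mg/kg by the intraperitoneal route; a higher number here means a stronger effect of the compound at the dose given, a lower number a weaker effect. Compound 1 `COCC(C(=O)N1CCN(c2cccc(C(F)(F)F)c2)CC1)N1C(=O)CCC1=O` gives 0%. Compound 2 `CC(C(=O)N1CCN(c2ccc(Cl)cc2)CC1)N1C(=O)CCC1=O` gives 0%, and compound 3 `CCC(C(=O)N1CCN(c2cccc(F)c2)CC1)N1C(=O)CCC1=O` gives 0%. On these numbers compound 2 stands level with compounds 1 and 3; all three values lie within the usual scatter of one another, so none can be set apart. Compound 4 `Cc1cccc(N2CCN(C(=O)C(C)N3C(=O)CCC3=O)CC2)c1`, not yet measured, differs from compound 2 in one place: 3-methylphenyl in place of 4-chlorophenyl on an amine nitrogen in a ring. Going by the values given here, no measured pair shows how such a change moves the read-out, so the expected step is no change at the digits printed from compound 2 to compound 4 (within the scatter), with no direction beyond the scatter. Compound 4 is therefore expected to give 0%, between 0% and 30%.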

Compound 4, a percentage reported as activity, at one dose (the size of the read-out at that dose, not a potency): 0%
Compound 4: middle estimate and measured number agree at the digits printed; measured number inside the range.
By their numbers in this assay, from the lowest: compounds 1, 2, 3 and 4 (each within the scatter of the next).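

In this assay, going by these compounds alone, 3-methylphenyl in place of 4-chlorophenyl on an amine nitrogen in a ring gives no change at the digits printed from compound 2 to compound 4 (within the scatter), the first comparison here of compounds that differ in one place. With compound 2 at 0% and compound 4 at 0%, this change brings no measurable effect at this dose, so the step cannot show whether this position matters. No measurement here offers an explanation. Still open, going by these compounds, is whether an amine or a carboxylic acid on the phenyl ring would give any effect in this assay at all.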